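Swapping furan-3-yl for thiophen-3-yl on a shared core

The compounds below may be only part of what the source reports. "The series", "measured", "known", "first", "only" and "open" are said of these compounds alone.

Of the compounds shown here, two with the same core have been measured in a functional assay on CCRF-CEM cells (Homo sapiens) for cytotoxicity, read by XTT assay, with a stated time of 3 days; a lower number here means a stronger inhibitor, a higher number a weaker inhibitor. Compound 1 `OC[C@H]1O[C@@H](n2cc(F)c3c(-c4ccc[nH]4)ncnc32)[C@H](O)[C@@H]1O`, carrying 1H-pyrrol-2-yl, gives 410 nM. Compound 2 `OC[C@H]1O[C@@H](n2cc(F)c3c(-c4ccoc4)ncnc32)[C@H](O)[C@@H]1O`, carrying furan-3-yl, gives 1000 nM, the higher of the two numbers and so the weaker inhibitor. Compound 3 `OC[C@H]1O[C@@H](n2cc(F)c3c(-c4ccsc4)ncnc32)[C@H](O)[C@@H]1O` has thiophen-3-yl in place of furan-3-yl on an aromatic carbon, so sulfur replaces oxygen in a five-membered aromatic ring. Going by the values given here, only one measured step offers any guide, and it involves a different pair of groups: a 2.4-fold higher number from compound 1 to compound 2 (0.39 log units; beyond the scatter). A step of about that size or smaller is therefore expected in this assay, with no firm direction. The expected change is small, an estimated 1.4-fold lower number from compound 2 to compound 3 (0.15 log units; within the scatter). For compound 3 the estimated value is 700 nM, with an expected range of 250 nM to 2000 nM.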

Compound 3, half-maximal inhibitory concentration: 560 nM
Beside the measured number, compound 3's estimate is 1.3-fold (0.10 log units) above it, within the range that was stated.
By their numbers in this assay, from the lowest: compounds 1, 3 and 2 (each within the scatter of the next, the first and the last beyond it).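

Replacing the oxygen of furan-3-yl with sulfur at this position, while the ring size and the counts of hydrogen-bond donors and acceptors stay the same, gives a 1.8-fold lower number from compound 2 to compound 3 (0.25 log units; within the scatter) in this assay, so this exchange cannot be told apart from assay noise. Thiophen-3-yl also cannot be separated from 1H-pyrrol-2-yl, with a 1.4-fold higher number from compound 1 to compound 3 (0.14 log units; within the scatter), even though compound 1 and compound 2 do differ beyond the scatter, so compound 3 lies within the scatter of both. No measurement of any property of these rings accompanies the numbers, so the data offer no explanation for them.

All three groups are five-membered aromatic rings with one hetero atom. As far as these compounds go, how a phenyl ring, an amine, a carboxylic acid or a longer alkyl chain on this carbon would behave in this assay remains open.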